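Second trifluoromethyl on a cytotoxicity-silent amide

This account rests on a few compounds, and the source may have more. Where it says the series, first, only, none or still open, it means among the compounds named here.

Four anilide compounds sharing one core are compared in an ADME assay on HEK293 cells (Homo sapiens) for cytotoxicity, read by MTT assay, with a stated time of 48 h; on this read-out higher numbers stand for weaker inhibition and lower numbers for stronger inhibition. Compound 1 `CCS(=O)(=O)Nc1ccc(NC(=O)c2cc(C(F)(F)F)cc(C(F)(F)F)c2)cc1C` gives 126000 nM. Compound 2 `COc1cc(NC(=O)c2cc(C(F)(F)F)cc(C(F)(F)F)c2)ccc1NS(C)(=O)=O` gives 42000 nM. Compound 3 `CCS(=O)(=O)Nc1ccc(NC(=O)c2cccc(C(F)(F)F)c2)cc1OC` carries a single trifluoromethyl group on its benzoyl ring. For compound 3 this assay reports only a limit, > 250000 nM, so its true value is not known; this limit stands out as the limit of > 250000 nM in this assay, at which 1 of the 3 values shown sits, which places compound 3 at the weak end of the measured compounds. Compound 4 `CCS(=O)(=O)Nc1ccc(NC(=O)c2cc(C(F)(F)F)cc(C(F)(F)F)c2)cc1OC` is not yet measured. It differs from compound 3 by trifluoromethyl in place of hydrogen on an aromatic carbon, which makes its benzoyl ring match the bis-trifluoromethyl ring of compound 1 and compound 2. For the measured compounds named here, no direct step between measured compounds exists for this change, but the two bis-trifluoromethyl compounds, compound 1 at 126000 nM and compound 2 at 42000 nM, both give measured numbers in this assay, which compound 3 does not. The step from compound 3 to compound 4 is therefore expected to run toward stronger inhibition, an at least 3.1-fold lower number from compound 3 to compound 4 (0.49 log units; beyond the scatter). Compound 4 is estimated at 80000 nM, within a range from 30000 nM to 250000 nM.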

Compound 4, half-maximal inhibitory concentration: > 250000 nM
Compound 4: no number, only a limit; the forecaster's own chance of this, stated with the estimate: 20%; middle value at least 3.1-fold (0.49 log units) away from the limit.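

Compound 4 in this assay reports only a limit, > 250000 nM, so trifluoromethyl in place of hydrogen on compound 3 does not bring a measured number, and the step between these two limits cannot be read. Methyl in place of hydrogen on the saturated chain carbon bound to the sulfonyl sulfur gives an at least 5.9-fold higher number from compound 2 to compound 4 (0.77 log units; beyond the scatter), so with this benzoyl ring in place, that small change at the sulfonyl end is a real one. Methoxy in place of methyl on an aromatic carbon gives an at least 1.9-fold higher number from compound 1 to compound 4 (0.29 log units; that floor lies within the scatter), which shows no firm change, as that floor lies within the scatter.

Going by these compounds, what trifluoromethyl does on its own at this place stays unknown, with two compounds resting at the same limit: the limit of > 250000 nM in this assay, at which 2 of the 4 values shown sit. Whether an amine at this place, or a longer chain on the sulfonyl sulfur, would change the number remains open.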